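Aryl piperazine variation in a trifluoromethyl benzylamide series

A few compounds are considered here, and "the series" means these few. Any claim that something is new, unique, unknown or untested is made for them only; others in the source may bear on it.

Compound 1 `CCCCN(C)c1cc(C(F)(F)F)ccc1CNC(=O)C(C)c1ccc(NS(C)(=O)=O)c(F)c1`: 1.2 nM
Compound 2 `CC(C(=O)NCc1ccc(C(F)(F)F)cc1N1CCC(Cc2ccccc2)CC1)c1ccc(NS(C)(=O)=O)c(F)c1`: 1.4 nM
Compound 3 `Cc1ccc(N2CCN(c3cc(C(F)(F)F)ccc3CNC(=O)C(C)c3ccc(NS(C)(=O)=O)c(F)c3)CC2)cc1`: 0.7 nM

All three were tested in an assay on CHO cells for antagonist activity at transient receptor potential cation channel subfamily V member 1 (Homo sapiens), read by FLIPR; a lower number here means a stronger inhibitor, a higher number a weaker inhibitor. Compound 3 gives the lowest of the three numbers, yet compound 1 and compound 2 both lie within the scatter of it, so no order among them can be read from these values. Compound 4 `COc1ccc(N2CCN(c3cc(C(F)(F)F)ccc3CNC(=O)C(C)c3ccc(NS(C)(=O)=O)c(F)c3)CC2)cc1` has not been measured; it differs from compound 3 only by methoxy in place of methyl on an aromatic carbon. Among the measured compounds shown here, no measured pair shows this change, so its size is unknown. A change of this kind is expected to leave the number within the scatter, in no particular direction, so the step of a 1.1-fold higher number from compound 3 to compound 4 (0.06 log units; within the scatter) is estimated as flat. Compound 4 is expected to give about 0.8 nM, between 0.3 nM and 2 nM.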

Compound 4, inhibition constant: 1.6 nM
Estimate against measurement, compound 4: 2.0-fold (0.30 log units) below; the measured number falls inside the stated range.
By their numbers in this assay, from the lowest: compounds 3, 1, 2 and 4 (each within the scatter of the next, the first and the last beyond it).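

In this assay, among the compounds shown here, the change from 4-methylphenyl to 4-methoxyphenyl gives the first single-place step, a 2.3-fold higher number from compound 3 to compound 4 (0.36 log units; beyond the scatter), a modest move beyond the scatter. This position, para to a large group, therefore responds to the exchange of methyl for methoxy, which adds one oxygen and one hydrogen-bond acceptor. Nothing at hand explains the step. The compounds shown leave open how an unsubstituted phenyl, a chloro or a nitrile would read at this position. They also leave open whether the oxygen or the longer substituent carries the step.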